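A few compounds are considered here, and "the series" means these few. Any claim that something is new, unique, unknown or untested is made for them only; others in the source may bear on it.

Compound 2, with the structure `O=c1cc(NC2CC2)cc(-c2ccccc2)o1`, is the starting point of this step. In a functional assay on DU-145 cells (Homo sapiens) for cytotoxicity, read by MTT assay, with a stated time of 72 h (on this read-out lower numbers stand for an effect already at smaller amounts and higher numbers for an effect only at larger amounts of compound), compound 2 gives only a limit, > 30 uM, and no number. Compound 1, `COc1cccc(Nc2cc(-c3ccccc3)oc(=O)c2)c1`, gives 0.66 uM in this assay. Compound 3, `COc1ccc(Nc2cc(C)oc(=O)c2)cc1`, likewise returns only a limit, > 30 uM, in this assay. Compound 2 thus sits at the limit of > 30 uM in this assay, at which 2 of the 3 values shown sit, which is not a measured potency but the edge of what the assay reports. Compound 4, `O=c1cc(Nc2ccccc2)cc(-c2ccccc2)o1`, differs from compound 2 in one place: phenyl in place of cyclopropyl on a nitrogen on an aromatic ring. For the measured compounds named here, no pair of measured compounds traces this exact change, so its size can only be estimated. Compound 1 carries an aryl group on that nitrogen together with the same phenyl on the core and reaches 0.66 uM, so a move to a potency well inside the measurable range is expected for compound 4. The step from compound 2 to compound 4 is expected to be an at least 20-fold lower number from compound 2 to compound 4 (1.30 log units; beyond the scatter) in this assay. Compound 4 is therefore estimated at 1.5 uM, within a range of 0.4 uM to 6 uM.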

Compound 4, concentration for half-maximal effect: 0.098 uM
Estimate against measurement, compound 4: 15-fold (1.18 log units) above; measured number below the stated range.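

In this assay, replacing cyclopropyl with phenyl on the nitrogen gives an at least 300-fold lower number from compound 2 to compound 4 (2.48 log units; beyond the scatter), showing that this position decides whether the shared core has a measurable effect at all. The aryl group on that nitrogen also needs no methoxy here: hydrogen in place of methoxy on an aromatic carbon gives a 6.7-fold lower number from compound 1 to compound 4 (0.83 log units; beyond the scatter). Compound 2 remains a limit of the assay, so this first step has only a minimum size and no exact one: the limit of > 30 uM in this assay, at which 2 of the 4 values shown sit.

The compounds shown leave open whether a benzyl group or a longer chain on that nitrogen would keep this effect, and how an amine or a carboxylic acid in place of that hydrogen would fare. Compound 3 differs from compound 4 in more than one place, and what the phenyl on the core contributes remains unresolved.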